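The source may hold more compounds than are shown below. What is called first, only, known or untested is meant among the compounds shown, and "the series" means these compounds.

Compound 1 `Nc1cccc(-c2cn3nc(-c4ccc(F)cc4)sc3n2)c1` sits at >= 250000 nM in a functional assay on L1210 cells (Mus musculus) for inhibition, read by cell counting, with a stated time of 2 days (on this read-out higher numbers stand for weaker inhibition and lower numbers for stronger inhibition), which is a limit of the assay rather than a number.
Compound 2 `Nc1cccc(-c2cn3nc(Cc4ccccc4)sc3n2)c1` gives 7400 nM in this assay.
Compound 3 `C=C(Br)C(=O)Nc1cccc(-c2cn3nc(Cc4ccccc4)sc3n2)c1` gives 3000 nM in this assay.

Among the two numbers shown, compound 2 stands highest, that is, as the weaker inhibitor; its nearest neighbour is compound 3, reached by a 2.5-fold lower number from compound 2 to compound 3 (0.39 log units; beyond the scatter), brought about by (1-bromoethenyl)carbonyl in place of hydrogen on a nitrogen on an aromatic ring. The other measured step, an at least 33-fold lower number from compound 1 to compound 2 (1.52 log units; beyond the scatter), came from benzyl in place of 4-fluorophenyl on an aromatic carbon. Compound 1 sits at the limit of >= 250000 nM in this assay, at which 1 of the 3 values shown sits, so that step is known only as a floor.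

Compound 4 `COc1ccc(Cc2nn3cc(-c4cccc(N)c4)nc3s2)cc1` differs from compound 2 by methoxy in place of hydrogen on an aromatic carbon. Neither measured step adds a small group to the benzyl ring: one swaps the whole group on that carbon, the other alters the amine. No shown step therefore bears directly on this change, and no movement beyond the scatter is expected in this assay. Compound 4 is accordingly estimated at 7000 nM, within 2500 nM to 20000 nM. The expected step is a 1.1-fold lower number from compound 2 to compound 4 (0.02 log units; within the scatter).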

Compound 4, half-maximal inhibitory concentration: 227000 nM
Compound 4: the middle estimate sits 32-fold (1.51 log units) below what was measured, outside the stated range (above it).
By their numbers in this assay, from the lowest: compound 3; then compound 2; then compound 4. At a limit, above all of these: compound 1.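

Earlier steps either swapped the whole group on this carbon or altered the amine, so they said nothing about small changes to the benzyl ring itself. This result shows that the ring is highly sensitive to such a change: in this assay, going from phenyl to 4-methoxyphenyl, which adds only 2 heavy atoms, gives a 31-fold higher number from compound 2 to compound 4 (1.49 log units; beyond the scatter). Nothing measured here explains why this small addition has so large an effect.

As far as these compounds go, it remains open whether this loss of inhibition is specific to methoxy or would follow from any group para to the large group, and a fluorine, a methyl or a hydroxyl on the same carbon would help to separate these cases. From the compounds shown here alone, whether methoxy would have the same effect on compound 3, which carries the (1-bromoethenyl)carbonyl group on its nitrogen, also remains open.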